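Swapping a carbamate for a sulfonamide on the ring amine

The compounds below may be only part of what the source reports. "The series", "measured", "known", "first", "only" and "open" are said of these compounds alone.

Measured so far:
- Compound 1, `CC(C)OC(=O)N1CCC(Oc2cccc3c2CCN3c2ccc(S(C)(=O)=O)cc2F)CC1`: 1000 nM in a functional assay on CHO-K1 cells for agonist activity at Glucose-dependent insulinotropic receptor (Homo sapiens), read by a luciferase reporter, with a stated time of 5 h; on this read-out lower numbers stand for an effect already at smaller amounts and higher numbers for an effect only at larger amounts of compound
- Compound 2, `CCCCOC(=O)N1CCC(Oc2ncnc3c2CCN3c2ccc(S(C)(=O)=O)cc2F)CC1`: 50.1 nM in this assay

Compound 2 stands at the lower of the two numbers measured in this assay. Compound 1 sits at a number higher by a margin well beyond the ordinary scatter of repeated runs, so compound 2 is the more potent of the pair. Compound 1 and compound 2 differ in more than one place, so no single structural cause can be drawn from that gap.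

Compound 3, `CC(C)S(=O)(=O)N1CCC(Oc2ncnc3c2CCN3c2ccc(S(C)(=O)=O)cc2F)CC1`, has not yet been measured. It differs from compound 2 in a single spot: isopropylsulfonyl in place of butoxycarbonyl on an amine nitrogen in a ring. Within the data shown here, the two groups are of similar size and both carry two hydrogen-bond acceptors, but one is a carbamate and the other a sulfonamide, and nothing among the measured compounds tests this exchange. The expectation is a modest shift, if any, in this assay, most likely toward a somewhat higher number, as expressed by the estimated step of a 2.0-fold higher number from compound 2 to compound 3 (0.30 log units; within the scatter). Compound 3 is thus expected to give about 100 nM, with a plausible range from 25 nM to 400 nM.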

Compound 3, half-maximal effective concentration: 1260 nM
Beside the measured number, compound 3's estimate is 13-fold (1.10 log units) below it; measured number outside the range, above it.
By their numbers in this assay, from the lowest: compound 2; then compounds 1 and 3 (each within the scatter of the next).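

Among these compounds, this is the first comparison here in which only one place changes, so the gap can be tied to the group on an amine nitrogen in a ring: in this assay, isopropylsulfonyl in place of butoxycarbonyl gives a 25-fold higher number from compound 2 to compound 3 (1.40 log units; beyond the scatter) and lies well beyond the scatter. The two groups have the same count of hydrogen-bond acceptors and nearly the same count of heavy atoms, so this position separates two groups that such simple counts barely distinguish. Nothing measured here gives a reason for the gap.

Still open, on these data alone, is whether the change in potency follows the switch from carbamate to sulfonamide or the switch from a butyl chain to an isopropyl end, as both happen in the same step, and a butylsulfonyl group on this same core would pull those two apart. Also open, as far as these compounds go, is where other groups on this nitrogen, such as an amide or a urea, would fall in this assay relative to compound 2 and compound 3.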